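Phenylsulfanyl in place of methoxyphenylsulfinyl on the shared core

A few compounds are considered here, and "the series" means these few. Any claim that something is new, unique, unknown or untested is made for them only; others in the source may bear on it.

Measured so far:
compound 1, `COc1ccc(CCCCCCCCOc2ccc(C[S+]([O-])c3cccc(C(=O)O)c3)nc2/C=C/C(=O)O)cc1`: 151 nM
compound 2, `COc1ccc(CCCCCCCCOc2ccc(C[S+]([O-])c3cccc(OC)c3)nc2/C=C/C(=O)O)cc1`: 232 nM

Both compounds were tested in an assay for binding affinity to leukotriene B4 receptor 1 (Homo sapiens); on this read-out higher numbers stand for weaker inhibition and lower numbers for stronger inhibition. Compound 1 gives 151 nM in this assay, and compound 2 gives 232 nM. Within the data shown here, the single step between them, a 1.5-fold higher number from compound 1 to compound 2 (0.19 log units; within the scatter), is within the scatter, so the two values cannot be ordered; compound 2 simply stands at the higher of the two numbers, with compound 1 its only neighbour.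

Compound 3, `COc1ccc(CCCCCCCCOc2ccc(CSc3ccccc3)nc2/C=C/C(=O)O)cc1`, is not yet measured. It differs from compound 2 by a group of 7 heavy atoms (6 carbon, 1 sulfur; one six-membered aromatic ring of carbon only) in place of a group of 10 heavy atoms (7 carbon, 2 oxygen, 1 sulfur; one six-membered aromatic ring of carbon only), on a saturated chain carbon bound to an aromatic carbon. Among the measured compounds shown here, the measured step from compound 1 to compound 2 concerns a different part of the molecule, the carboxy and methoxy on an aromatic carbon, and it was within the scatter; no measured pair shows what the loss of the sulfinyl oxygen and of the methoxy does. For the measured compounds named here, with no direct precedent, and with the only known step being small, compound 3 is expected to land near compound 2, at 300 nM, between 100 nM and 900 nM. This estimate means a step of a 1.3-fold higher number from compound 2 to compound 3 (0.11 log units; within the scatter), which is expected to stay within the scatter of this assay.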

Compound 3, inhibition constant: 74 nM
Estimate against measurement, compound 3: 4.1-fold (0.61 log units) above, outside the stated range (below it).
By their numbers in this assay, from the lowest: compound 3; then compounds 1 and 2 (each within the scatter of the next).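

In this assay, the group on the saturated chain carbon bound to an aromatic carbon proves able to move the number, which the earlier swap of carboxy for methoxy did not show: phenylsulfanyl brings a 3.1-fold lower number from compound 2 to compound 3 (0.50 log units; beyond the scatter), and a 2.0-fold lower number from compound 1 to compound 3 (0.31 log units; beyond the scatter), both steps beyond the scatter. Neither the sulfinyl oxygen nor a carboxy or methoxy on the aromatic ring is therefore needed for binding at this level, and compound 3, the simplest of the three at this place, has the lowest number and so the strongest binding of the set. No measurement shown here explains this gain.

Each step changes the sulfur and the ring substituent together, so the compounds shown cannot tell how much of the gain belongs to the loss of the sulfinyl oxygen and how much to the loss of the methoxy or carboxy. A phenylsulfinyl group or a methoxyphenylsulfanyl group would separate the two, and a sulfone, or an amine on the aromatic ring, would show how far this place tolerates other groups.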